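A few compounds are considered here, and "the series" means these few. Any claim that something is new, unique, unknown or untested is made for them only; others in the source may bear on it.

Measured in a functional assay on blood (Homo sapiens), with a stated time of 60 min, in the presence of a further agent that is not named here; on this read-out higher numbers stand for an effect only at larger amounts of compound and lower numbers for an effect already at smaller amounts:
- Compound 1 `O=C(Oc1ccccc1)C1(S(=O)(=O)c2ccc(Oc3ccc(OC(F)(F)F)cc3)cc2)CCC2(CCNCC2)C1`: 900 nM
- Compound 2 `NC(=O)C1(S(=O)(=O)c2ccc(Oc3ccc(OC(F)(F)F)cc3)cc2)CCC2(CCNCC2)C1`: 3700 nM
- Compound 3 `O=C(Nc1ccccn1)C1(S(=O)(=O)c2ccc(Oc3ccc(OC(F)(F)F)cc3)cc2)CCC2(CCNCC2)C1`: > 15000 nM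

Compound 3 reads > 15000 nM, which is a limit of the assay and not a number. Compound 1 holds the lowest number, and compound 2 comes nearest to it. Compound 4 `O=C(Nc1ccccc1O)C1(S(=O)(=O)c2ccc(Oc3ccc(OC(F)(F)F)cc3)cc2)CCC2(CCNCC2)C1` is unmeasured and differs from compound 1 thus: (2-hydroxyphenyl)amino in place of phenoxy on a carbonyl carbon. Two measured steps also replace phenoxy on the carbonyl carbon with a nitrogen group, and both raised the number: a 4.1-fold higher number from compound 1 to compound 2 (0.61 log units; beyond the scatter) and an at least 16-fold higher number from compound 1 to compound 3 (1.22 log units; beyond the scatter). Adding a ring to the nitrogen raised it further: an at least 4.0-fold higher number from compound 2 to compound 3 (0.60 log units; beyond the scatter). Going by the values given here, compound 3 is the closest precedent, though its ring differs, so a sizeable rise in this assay is expected. The expected change is a 7.8-fold higher number from compound 1 to compound 4 (0.89 log units; beyond the scatter). The estimate for compound 4 is 7000 nM, with a range of 2000 nM to 25000 nM.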

Compound 4, half-maximal effective concentration: > 15000 nM
Compound 4 was reported as a limit (the forecaster's own chance of this, stated with the estimate: 35%); middle value at least 2.1-fold (0.33 log units) from the limit.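

In this assay compound 4 gives > 15000 nM, which is a limit of the assay and not a number. Here (2-hydroxyphenyl)amino gives an at least 16-fold higher number from compound 1 to compound 4 (1.22 log units; beyond the scatter), and the same ring on the amide nitrogen gives an at least 4.0-fold higher number from compound 2 to compound 4 (0.60 log units; beyond the scatter), so the rise seen with compound 3 does not need its pyridin-2-yl ring. The step between compound 3 and compound 4 cannot be read: the limit of > 15000 nM in this assay, at which 2 of the 4 values shown sit.

Still open, as far as these compounds go, is how far either compound lies past that limit. Also open, from the compounds shown here alone, is how a methyl group on the amide nitrogen, or a carboxylic acid on the carbonyl carbon, would read.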